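The source may hold more compounds than are shown below. What is called first, only, known or untested is meant among the compounds shown, and "the series" means these compounds.

Measured in a functional assay on MCF7 cells (Homo sapiens) for antiproliferative activity, read by CCK-8 assay, with a stated time of 48 h; on this read-out higher numbers stand for weaker inhibition and lower numbers for stronger inhibition:
compound 1, `COc1cc(-c2nnc(-n3[se]c4ccccc4c3=O)s2)cc(OC)c1OC`: 3440 nM
compound 2, `COc1ccc(-c2nnc(-n3[se]c4ccccc4c3=O)s2)cc1`: 10000 nM
compound 3, `O=c1c2ccccc2[se]n1-c1nnc(-c2ccc(F)cc2)s1`: 61500 nM

Compound 3 stands at the highest number of the three in this assay; its gap to compound 2 is beyond the scatter, and its gap to compound 1 is wider still. The next compound in the series is compound 4, `O=c1c2ccccc2[se]n1-c1nnc(-c2ccccc2Br)s1`. The change from compound 3 is 2-bromophenyl in place of 4-fluorophenyl on an aromatic carbon. Within the data shown here, only one measured step touches the same phenyl ring: a 6.2-fold higher number from compound 2 to compound 3 (0.79 log units; beyond the scatter). That step shows that exchanging the group on this ring can move the number by a modest amount, but it covers neither bromine nor a change of where the group sits on the ring. Among the measured compounds shown here, the direction of the present change is therefore not fixed by the data, and no step bears on it directly. Compound 4 is expected to land near compound 3, with a wide range around the estimate, at 40000 nM (from 8000 nM to 120000 nM). The step this estimate implies is a 1.5-fold lower number from compound 3 to compound 4 (0.19 log units; within the scatter), and whether it will fall beyond the scatter is open.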

Compound 4, half-maximal inhibitory concentration: 59400 nM
The estimate for compound 4 lay 1.5-fold (0.17 log units) below the measured number, and the stated range covers the measured number.
By their numbers in this assay, from the lowest: compound 1; then compound 2; then compounds 4 and 3 (each within the scatter of the next).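

In this assay, putting 2-bromophenyl in place of 4-fluorophenyl on the aromatic carbon of the five-membered ring gives a 1.0-fold lower number from compound 3 to compound 4 (0.02 log units; within the scatter), so at this position the halogen and its place on the phenyl ring were exchanged together with no shift beyond the scatter. The earlier step, a 6.2-fold higher number from compound 2 to compound 3 (0.79 log units; beyond the scatter), showed that an exchange on this ring can move the number; the new pair shows that not every exchange there does. No measurement at hand offers an explanation for this flat step.

The pair cannot tell whether the identity of the halogen and its place on the ring each leave the number unchanged or whether two separate effects offset each other, and a compound that differs from compound 3 in only one of these two respects would be needed to separate them. Also open is whether the flat step extends beyond halogens, for instance to an amine or a carboxylic acid on the phenyl ring, as the compounds shown carry neither group.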